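Sulfonamide series: cytotoxicity notes ahead of compound 4

The source may report more compounds than this note shows. Statements on the series, on what has been measured and on what is new or still open speak of the compounds shown alone.

Compound 1, `O=S(=O)(Nc1ccc2oc(-c3ccccc3)nc2c1)c1ccc(Cl)c(Cl)c1`: in an ADME assay on HEK293 cells (Homo sapiens) for cytotoxicity, read by resazurin assay, with a stated time of 48 h (on this read-out lower numbers stand for higher toxicity in this test and higher numbers for lower toxicity in this test), compound 1 gives 71000 nM.
Compound 2, `CS(=O)(=O)Nc1ccc2oc(-c3ccccc3)nc2c1`: in this assay compound 2 gives only a limit, > 100000 nM.
Compound 3, `COc1ccc(S(=O)(=O)Nc2ccc3oc(-c4ccccc4)nc3c2)cc1`: in this assay compound 3 gives 91000 nM.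

Compound 1 holds the lowest of the two numbers, though compound 3 sits within the scatter of it: a 1.3-fold higher number from compound 1 to compound 3 (0.11 log units; within the scatter). Compound 2 rests at the limit of > 100000 nM in this assay, at which 1 of the 3 values shown sits, giving an at least 1.4-fold higher number from compound 1 to compound 2 (0.14 log units; that floor lies within the scatter). Compound 4, `O=[N+]([O-])c1cc(S(=O)(=O)Nc2ccc3oc(-c4ccccc4)nc3c2)ccc1Cl`, differs from compound 1 by nitro in place of chloro on an aromatic carbon. Going by the values given here, no measured step swaps a single group on the aryl attached to the sulfonyl sulfur; the two steps that replace that aryl whole both stay within the scatter. No step beyond the scatter is therefore expected in this assay. Compound 4 is expected to give 80000 nM (range 40000 nM to 100000 nM), an expected 1.1-fold higher number from compound 1 to compound 4 (0.05 log units; within the scatter).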

Compound 4, half-maximal cytotoxic concentration: 90000 nM
Estimate against measurement, compound 4: 1.1-fold (0.05 log units) below; low and high end bracket the measured number.
By their numbers in this assay, from the lowest: compounds 1, 4 and 3 (each within the scatter of the next). At a limit, above all of these: compound 2.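

In this assay the swap reads as a 1.3-fold higher number from compound 1 to compound 4 (0.10 log units; within the scatter) and is the only single-group change shown on the aryl attached to the sulfonyl sulfur. This position, ortho to a chloro group and meta to a large group, thus takes nitro, with more heavy atoms and more hydrogen-bond acceptors than chloro, without a step beyond the scatter. Nothing shown gives a measured property that bears on this step. Going by these compounds, whether an amine or a carboxylic acid at this position would also stay within the scatter remains open, as does the effect of replacing the chloro group that stays in compound 4.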